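Trimming the amide in a shared pyridinone-bearing series

The compounds below may be only part of what the source reports. "The series", "measured", "known", "first", "only" and "open" are said of these compounds alone.

Of the compounds shown here, three of one series have been measured in a physicochemical assay for lipophilicity, using the shake flask method, measured as octanol-water partition, at pH 7.4; a higher number here means a more lipophilic compound, a lower number a more polar compound. Compound 1 `CN(C)C(=O)CN1CCC(c2cc3c(-c4ccc(=O)n(C5CCC5)c4)ccnc3[nH]2)CC1` gives 1.9, and compound 2 `COc1cc(F)ccc1-c1ccnc2[nH]c(C3CCN(CC(=O)N(C)C)CC3)cc12` gives 2.9. Compound 3 `CC(C)n1cc(-c2ccnc3[nH]c(C4CCN(CC(=O)N5CCCC5)CC4)cc23)ccc1=O` gives 2.1. On these numbers compound 3 sits close to compound 1, the two within the scatter of the method, while compound 2 lies clearly higher than compound 3, beyond the scatter. Among the compounds with values here, no pair among the measured compounds differs in a single place, so no measured step guides the next one directly.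

Compound 4 `CC(C)n1cc(-c2ccnc3[nH]c(C4CCN(CC(=O)N(C)C)CC4)cc23)ccc1=O` differs from compound 3 in one place: dimethylamino in place of pyrrolidin-1-yl on a carbonyl carbon. The carbonyl carbon that carries the group sits on a saturated chain carbon, and the rest of the molecule is unchanged.

For this assay the shrinking of the amine side of the amide is expected to lower the number by a small amount, at the edge of the scatter, so that the step of a number 0.40 log units lower from compound 3 to compound 4 (beyond the scatter) is estimated to be a modest decrease. Compound 4 is therefore expected at 1.7, within a range from 1.3 to 2.1.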

Compound 4, distribution coefficient: 1.9
Estimate against measurement, compound 4: 0.20 log units below; the measured number falls inside the stated range.
By their numbers in this assay, from the lowest: compounds 1, 4 and 3 (each within the scatter of the next); then compound 2.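

In this assay, within the data shown here, dimethylamino in place of pyrrolidin-1-yl on a carbonyl carbon gives a number 0.20 log units lower from compound 3 to compound 4 (within the scatter) and thus provides the first single-place reading at this amide, where the two groups cannot be told apart. Among these compounds, on the aromatic nitrogen, isopropyl in place of cyclobutyl gives no change at the digits printed from compound 1 to compound 4 (within the scatter) and likewise separates nothing, whereas a group with a six-membered aromatic ring with 1 hetero atom, in place of one with a ring of carbon only, gives a number 1.00 log units lower from compound 2 to compound 4 (beyond the scatter) on an aromatic carbon, the only one of these steps beyond the scatter. No measurement at hand accounts for any of these steps.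

On these data alone, it remains open whether morpholine or piperidine on the same carbonyl carbon would also stay within the scatter of compound 3, or whether a carboxylic acid in place of the amide would not. Also open, as far as these compounds go, is how methyl or a longer chain on the aromatic nitrogen would compare with compound 4 in this assay and whether the reading there holds beyond this one pair.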